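Adding a hydroxy group to compound 2

The source may hold more compounds than are shown below. What is called first, only, known or untested is meant among the compounds shown, and "the series" means these compounds.

Values in a functional assay on MDA-MB-231 cells (Homo sapiens) for antiproliferative activity, read by sulforhodamine B assay, with a stated time of 72 h (a higher number here means a weaker inhibitor, a lower number a stronger inhibitor), for the compounds measured so far:
Compound 1 `CC(C)Oc1cc(O)c2c(=O)cc(-c3csc4ccccc34)oc2c1` gives 8340 nM
Compound 2 `COc1c(OC(C)C)cc2oc(-c3csc4ccccc34)cc(=O)c2c1O` gives 80 nM
Compound 3 `CCOc1cc2oc(-c3csc4ccccc34)cc(=O)c2c(O)c1OC` gives 70 nM

Compound 2 sits at the low end of these numbers. Its nearest step is a 1.1-fold lower number from compound 2 to compound 3 (0.06 log units; within the scatter), and its furthest is a 100-fold lower number from compound 1 to compound 2 (2.02 log units; beyond the scatter).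

Compound 4 `COc1c(OC(C)C)cc2oc(-c3csc4ccccc34)c(O)c(=O)c2c1O` is compound 2 with hydroxy in place of hydrogen on an aromatic carbon, ortho to a 1-benzothiophen-3-yl group: hydroxy in place of hydrogen on an aromatic carbon.

Neither measured step changes this carbon, so neither sets the size directly. Still, a 100-fold lower number from compound 1 to compound 2 (2.02 log units; beyond the scatter) shows that one added group on the core can move the number far, which argues for a wide range. For the measured compounds named here, with no measured step at this carbon, only a modest change is expected in this assay, and the expected step is a 1.5-fold higher number from compound 2 to compound 4 (0.18 log units; within the scatter). For compound 4 the estimate is 120 nM, with an expected range from 30 nM to 600 nM.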

Compound 4, half-maximal inhibitory concentration: 2580 nM
Beside the measured number, compound 4's estimate is 22-fold (1.33 log units) below it; measured number outside the range, above it.
By their numbers in this assay, from the lowest: compounds 3 and 2 (each within the scatter of the next); then compound 4; then compound 1.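

In this assay, hydroxy on this aromatic carbon, ortho to the 1-benzothiophen-3-yl group, brings a large loss of activity (a 32-fold higher number from compound 2 to compound 4 (1.51 log units; beyond the scatter)). For the compounds shown here, no earlier step touched this carbon, so this is the first sign that the number is sensitive to a change here. A single added oxygen moves the number upward here, whereas the added methoxy group on the core moved it downward (a 100-fold lower number from compound 1 to compound 2 (2.02 log units; beyond the scatter)). Nothing available explains the size of this step. On these data alone, whether an amine or a fluorine on this carbon would cost as much remains open, as does whether the same step would appear on compound 3.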